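Ethoxy substitution in a cytotoxicity series: working notes

This account rests on a few compounds, and the source may have more. Where it says the series, first, only, none or still open, it means among the compounds named here.

Compound 1, `CCOc1ccc2nc(Nc3nc4ccccc4s3)sc2c1`: in a functional assay on U-937 cells (Homo sapiens) for cytotoxicity, read by MTT assay, with a stated time of 48 h (a lower number here means a stronger inhibitor, a higher number a weaker inhibitor), compound 1 gives > 50000 nM, which is a limit of the assay.
Compound 2, `c1ccc2sc(Nc3nc4ccccc4s3)nc2c1`: compound 2 gives 40000 nM.
Compound 3, `S=C(Nc1ccccc1)Nc1nc2ccccc2s1`: compound 3 gives > 50000 nM, again a limit.

Compound 1 and compound 2 share a core and differ by ethoxy in place of hydrogen on an aromatic carbon, which gives an at least 1.2-fold higher number from compound 2 to compound 1 (0.09 log units; that floor lies within the scatter). The size of that step is known only as a floor because of the limit of > 50000 nM in this assay, at which 2 of the 3 values shown sit. Compound 3 carries a different core; how it differs from compound 2 is not broken down here.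

Compound 4, `CCOc1ccc2nc(NC(=S)Nc3ccccc3)sc2c1`, is not yet measured. It differs from compound 3 by ethoxy in place of hydrogen on an aromatic carbon, the same change as that from compound 2 to compound 1. The step from compound 3 to compound 4 is expected to be a step that the limit leaves unreadable from compound 3 to compound 4. That expectation rests on compound 3 sitting at a limit and on an at least 1.2-fold higher number from compound 2 to compound 1 (0.09 log units; that floor lies within the scatter). Compound 4 is therefore estimated at 90000 nM, most likely reported again only as a limit.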

Compound 4, half-maximal inhibitory concentration: 37700 nM
The estimate for compound 4 lay 2.4-fold (0.38 log units) above the measured number, and the stated range covers the measured number.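

In this assay, ethoxy in place of hydrogen on an aromatic carbon gives an at least 1.3-fold lower number from compound 3 to compound 4 (0.12 log units; that floor lies within the scatter). Set beside the same change on the core of compound 2, the two steps compare as follows: the same change on two cores in this assay, an at least 1.2-fold higher number (0.09 log units; that floor lies within the scatter) from compound 2 to compound 1 and an at least 1.3-fold lower number (0.12 log units; that floor lies within the scatter) from compound 3 to compound 4; the limit leaves it open whether they differ. The series therefore gives no measured size that carries from one core to the other, and it does not show that the change acts differently on the two cores, a question held open by the assay limit: the limit of > 50000 nM in this assay, at which 2 of the 4 values shown sit.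

As far as these compounds go, the true size of the ethoxy step on either core remains open, with each step known only as a floor. Also open, from the compounds shown here alone, is how a methoxy group, a longer alkoxy chain or an amine would read at the same position on these cores.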